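Ester Variation on a Nitro-Trifluoromethyl Thiochromenone Core

This account rests on a few compounds, and the source may have more. Where it says the series, first, only, none or still open, it means among the compounds named here.

Measured compounds and their values in an ADME assay on cells (Hepatocyte, Mus musculus) for metabolic stability, with a stated time of 30 min; on this read-out lower numbers stand for a less stable compound and higher numbers for a more stable compound:
- compound 1 `NC1CCC(CN2CCN(c3cc(=O)c4cc(C(F)(F)F)cc([N+](=O)[O-])c4s3)CC2)CC1`: 107%
- compound 2 `O=C(OC1CCC(CN2CCN(c3cc(=O)c4cc(C(F)(F)F)cc([N+](=O)[O-])c4s3)CC2)CC1)c1cccs1`: 1.8%
- compound 3 `COc1ccc(C(=O)OC2CCC(CN3CCN(c4cc(=O)c5cc(C(F)(F)F)cc([N+](=O)[O-])c5s4)CC3)CC2)cc1`: 31%

Compound 3 holds the second highest of the three numbers in this assay. It sits nearer to compound 2, as the step of a number 29.2 percentage points higher from compound 2 to compound 3 (beyond the scatter) shows, and further from compound 1, whose amino group was replaced in a number 76 percentage points lower from compound 1 to compound 3 (beyond the scatter). Compound 4 `Cc1ccc(C(=O)OC2CCC(CN3CCN(c4cc(=O)c5cc(C(F)(F)F)cc([N+](=O)[O-])c5s4)CC3)CC2)cc1` is the next step, differing from compound 3 only at the ester: methyl in place of methoxy on an aromatic carbon.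

Within the data shown here, no measured pair changes a methoxy to a methyl, so no step bears directly on this change. Among the measured compounds shown here, the one step that alters the aryl part of the ester, a number 29.2 percentage points higher from compound 2 to compound 3 (beyond the scatter), was modest, and it involved a change of the whole ring, a larger alteration than the one here. Both esters, compound 2 and compound 3, lie far below compound 1, so compound 4 is expected to remain in the lower region as well. The step is estimated to be within the scatter or a small decrease, a number 9 percentage points lower from compound 3 to compound 4 (within the scatter). Compound 4 is expected to give 22% in this assay, within a range from 3% to 50%.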

Compound 4, percent of the compound remaining: 18%
Estimate against measurement, compound 4: 4 percentage points above, within the range that was stated.
By their numbers in this assay, from the lowest: compound 2; then compound 4; then compound 3; then compound 1.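

In this assay, the new result shows that this para position on the ester's aromatic ring matters even for a small change, since a number 13 percentage points lower from compound 3 to compound 4 (beyond the scatter) comes from swapping methoxy for methyl alone, whereas the earlier aryl comparison replaced the whole ring. The 4-methylphenyl ester also stands apart from the thiophen-2-yl ester, with a number 16.2 percentage points higher from compound 2 to compound 4 (beyond the scatter), yet this gain remains small beside the drop from the amino compound, a number 89 percentage points lower from compound 1 to compound 4 (beyond the scatter). Nothing measured here gives a reason for these differences.

Still open is where a plain phenyl ester, or a 4-chlorophenyl or 4-aminophenyl ester, would fall among these aryl esters. Going by these compounds, it is also open whether an amide linkage in place of the ester would move the number closer to that of compound 1.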